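Removing a tertiary alcohol from the piperidine: compound 3 to 4

The source may report more compounds than this note shows. Statements on the series, on what has been measured and on what is new or still open speak of the compounds shown alone.

Measured so far:
- compound 1, `CC(C)NC(=O)[C@H]1CC[C@@H](n2/c(=N/C(=O)c3ccc(F)cc3)[nH]c3ccc(CN4CCCCC4)cc32)CC1`: 302 mL.min-1.g-1
- compound 2, `COC(=O)[C@H]1CC[C@@H](n2/c(=N/C(=O)c3ccccc3)[nH]c3ccc(CN4CCCCC4)cc32)CC1`: 85 mL.min-1.g-1
- compound 3, `CC(C)NC(=O)[C@H]1CC[C@@H](n2/c(=N/C(=O)c3ccccc3)[nH]c3ccc(CN4CCC(C(C)(C)O)CC4)cc32)CC1`: 40 mL.min-1.g-1

Three compounds sharing one core have been run in an in vitro ADME assay on microsomes from liver (Homo sapiens) for metabolic stability; a higher number here means faster removal of the compound, a lower number slower removal. Compound 3 gives the lowest of the three numbers; compound 2 stands nearest to it, and that gap already lies beyond the scatter, while compound 1 lies furthest away, also beyond the scatter.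

Compound 4, `CC(C)NC(=O)[C@H]1CC[C@@H](n2/c(=N/C(=O)c3ccccc3)[nH]c3ccc(CN4CCCCC4)cc32)CC1`, has not yet been measured in this assay. Relative to compound 3 it carries one change: hydrogen in place of 1-hydroxy-1-methylethyl on a saturated ring carbon. Within the data shown here, no pair among the measured compounds differs in that one place alone, so the expected step rests on a comparison with compound 3 and on what compounds 1 and 2, which both carry a plain piperidin-1-yl group, show.

Because compound 1 gives 302 mL.min-1.g-1 and compound 2 gives 85 mL.min-1.g-1, both well above the value of compound 3, the step of a 3.8-fold higher number from compound 3 to compound 4 (0.57 log units; beyond the scatter) is expected to be upward and beyond the scatter. Compound 4 is therefore estimated at 150 mL.min-1.g-1, within a range from 60 mL.min-1.g-1 to 380 mL.min-1.g-1.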

Compound 4, intrinsic clearance in microsomes: 203 mL.min-1.g-1
The estimate for compound 4 lay 1.4-fold (0.13 log units) below the measured number; the range from low to high includes it.
By their numbers in this assay, from the lowest: compound 3; then compound 2; then compounds 4 and 1 (each within the scatter of the next).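

In this assay, the piperidine change can now be read on its own: hydrogen in place of 1-hydroxy-1-methylethyl on the saturated ring carbon gives a 5.1-fold higher number from compound 3 to compound 4 (0.71 log units; beyond the scatter) with the rest of the molecule unchanged. With piperidin-1-yl held constant, two further places can also be read: isopropylamino in place of methoxy on the carbonyl carbon gives a 2.4-fold higher number from compound 2 to compound 4 (0.38 log units; beyond the scatter) and hydrogen in place of fluoro on the aromatic carbon gives a 1.5-fold lower number from compound 1 to compound 4 (0.17 log units; within the scatter) as a step that cannot be told from repeat measurements. Nothing shown here accounts for any of these steps.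

The compounds leave open whether the hydroxyl group itself matters, since neither an isopropyl group nor a 1-methoxy-1-methylethyl group appears at this position. They also leave open whether a hydroxyl or hydroxymethyl group placed there would give a similar number.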